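This account rests on a few compounds, and the source may have more. Where it says the series, first, only, none or still open, it means among the compounds named here.

Three compounds that share one core and differ only in configuration have been tested in a functional assay on MDA-MB-231 cells (Homo sapiens) for inhibition, read by MTT assay, with a stated time of 72 h; a higher number here means a weaker inhibitor, a lower number a stronger inhibitor: compound 1 `CC1=NN(c2ccccc2)C(=O)[C@]12C(=O)C=CC[C@H]2c1cccc(C)c1` gives 10300 nM, compound 2 `CC1=NN(c2ccccc2)C(=O)[C@@]12C(=O)C=CC[C@H]2c1cccc(C)c1` gives 6610 nM, and compound 3 `CC1=NN(c2ccccc2)C(=O)[C@@]12C(=O)C=CC[C@@H]2c1cccc(C)c1` gives 6800 nM. Compound 2 stands level with the other two, as shown by a 1.6-fold lower number from compound 1 to compound 2 (0.19 log units; within the scatter) and a 1.0-fold higher number from compound 2 to compound 3 (0.01 log units; within the scatter). The mirror-image pair agrees as well, with a 1.5-fold lower number from compound 1 to compound 3 (0.18 log units; within the scatter).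

Compound 4 `CC1=NN(c2ccccc2)C(=O)[C@@]12C(=O)C=CC[C@H]2c1ccccc1` is drawn with the configuration of compound 2 but has hydrogen in place of methyl on an aromatic carbon, (hydrogen in place of methyl on an aromatic carbon), so 3-methylphenyl becomes phenyl. Within the data shown here, none of the measured steps touches this methyl, so they bear on the change only indirectly and give no sign of its size or direction. With no measured guide to a shift, the expectation stays anchored on compound 2 at 6610 nM in this assay, and no step beyond the scatter is expected. The estimated change is a 1.2-fold higher number from compound 2 to compound 4 (0.08 log units; within the scatter). For compound 4 the expected value is 8000 nM, with an estimated range of 3500 nM to 18000 nM.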

Compound 4, half-maximal inhibitory concentration: 5500 nM
The estimate for compound 4 lay 1.5-fold (0.16 log units) above the measured number; the range from low to high includes it.
By their numbers in this assay, from the lowest: compounds 4, 2, 3 and 1 (each within the scatter of the next).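

Compound 4 brings the first change outside configuration in this set: in this assay, going from 3-methylphenyl to phenyl gives a 1.2-fold lower number from compound 2 to compound 4 (0.08 log units; within the scatter) and so leaves no readable shift. On this aromatic carbon, then, the methyl is not required for the level of compound 2, at least in this one configuration and in this one cell assay. The facts at hand concern configuration alone, so none of them bears on this step.

The compounds shown leave open whether a larger or differently charged group at this place, such as a methoxy group, an amine or a carboxylic acid, would move the number beyond the scatter. They also leave open whether hydrogen in place of methyl would read the same in the configurations of compound 1 and compound 3.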